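The source may report more compounds than this note shows. Statements on the series, on what has been measured and on what is new or still open speak of the compounds shown alone.

Measured in an ADME assay on TZM cells (Homo sapiens) for cytotoxicity, read by CCK-8 assay, with a stated time of 2 days; on this read-out higher numbers stand for lower toxicity in this test and lower numbers for higher toxicity in this test:
compound 1 `CC(=O)Oc1ccc(/C=C/S(=O)(=O)CCc2ccc(NC(=O)C3CCCCC3)cc2)cc1OC(C)=O` gives 169000 nM
compound 2 `CC(=O)Oc1ccc(/C=C/S(=O)(=O)CCc2ccc(NC(=O)c3ccc(C)cc3)cc2)cc1OC(C)=O` gives 177000 nM
compound 3 `O=C(Nc1ccc(CCS(=O)(=O)/C=C/c2ccc(O)c(O)c2)cc1)C1CCCCC1` gives 638000 nM

Compound 3 gives the highest number of the three; its nearest neighbour is compound 2, and that gap lies beyond the scatter. The difference between the core of compound 1 and the core of compound 3 is not broken down here. Within the core of compound 1, the change 4-methylphenyl in place of cyclohexyl on a carbonyl carbon gives a 1.0-fold higher number from compound 1 to compound 2 (0.02 log units; within the scatter) in this assay. Compound 4 `Cc1ccc(C(=O)Nc2ccc(CCS(=O)(=O)/C=C/c3ccc(O)c(O)c3)cc2)cc1` is not yet measured; it carries the same change on the core of compound 3, namely (4-methylphenyl in place of cyclohexyl on a carbonyl carbon), at a place described the same way in both pairs. With a single earlier instance to rest on, the step is expected to be a 1.0-fold higher number from compound 3 to compound 4 (0.01 log units; within the scatter) in this assay because the earlier step of a 1.0-fold higher number from compound 1 to compound 2 (0.02 log units; within the scatter) lay within the scatter. For compound 4 in this assay a value of 650000 nM is estimated, with a range from 320000 nM to 1300000 nM.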

Compound 4, half-maximal cytotoxic concentration: 168000 nM
Compound 4: the middle estimate sits 3.9-fold (0.59 log units) above what was measured, outside the stated range (below it).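

In this assay, 4-methylphenyl in place of cyclohexyl on a carbonyl carbon gives a 3.8-fold lower number from compound 3 to compound 4 (0.58 log units; beyond the scatter), so the change does not carry over unaltered from the core of compound 1 to the core of compound 3: the same change on two cores in this assay, a 1.0-fold higher number (0.02 log units; within the scatter) from compound 1 to compound 2 and a 3.8-fold lower number (0.58 log units; beyond the scatter) from compound 3 to compound 4, 4.0-fold (0.60 log units) apart, beyond the scatter of two such steps

In these two pairs, the size of the step depends on the core, and a step within the scatter on one core is no safe guide to the other. This rests on a single pair per core and does not show which part of the difference between the cores matters, nor how the change behaves on any further core.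

Still open, from the compounds shown here alone, is whether the same core dependence holds for other groups on this carbonyl carbon, such as an unsubstituted phenyl, a straight butyl chain or a phenyl carrying an amine.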